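The source may hold more compounds than are shown below. What is called first, only, known or untested is meant among the compounds shown, and "the series" means these compounds.

Working notes on the series.

The shared core of compound 1 `COc1cc(-c2ccnc3cc(-c4c[nH]c5ccccc45)nn23)cc(OC)c1OC` carries a 1H-indol-3-yl group; in a functional assay on HeLa cells (Homo sapiens) for inhibition, read by CCK-8 assay, with a stated time of 48 h (on this read-out lower numbers stand for stronger inhibition and higher numbers for weaker inhibition), compound 1 gives 195 nM. Among the three measured compounds this places compound 1 second highest: compound 3 `COc1cc(-c2ccnc3cc(-c4ccc(C)c(C)c4)nn23)cc(OC)c1OC` gives 241 nM, and compound 2 `COc1cc(-c2ccnc3cc(-c4ccc(C)cc4)nn23)cc(OC)c1OC` gives 21 nM.

Compound 4 `COc1cc(-c2ccnc3cc(-c4ccc(N(C)C)cc4)nn23)cc(OC)c1OC` is not yet measured. It differs from compound 1 by 4-(dimethylamino)phenyl in place of 1H-indol-3-yl on an aromatic carbon.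

Among the compounds with values here, two measured steps bear on this change. The closest is a 9.3-fold lower number from compound 1 to compound 2 (0.97 log units; beyond the scatter), where a phenyl bearing a single substituent at the same ring position as the dimethylamino group of compound 4 replaced the 1H-indol-3-yl group. By contrast a 1.2-fold higher number from compound 1 to compound 3 (0.09 log units; within the scatter), and an 11-fold higher number from compound 2 to compound 3 (1.06 log units; beyond the scatter) shows that a second methyl on the phenyl reverses the gain. Compound 4 carries one substituent only, so the step from compound 1 is expected to resemble the step to compound 2 rather than the step to compound 3, with some allowance for the dimethylamino group being untested here.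

The expected step for compound 4 is therefore a lower number, a 3.9-fold lower number from compound 1 to compound 4 (0.59 log units; beyond the scatter), beyond the scatter. Compound 4 is estimated at 50 nM in this assay, with a range from 15 nM to 180 nM.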

Compound 4, half-maximal inhibitory concentration: 378 nM
Compound 4: middle estimate off by 7.6-fold (0.88 log units), on the low side; measured number outside the range, above it.
By their numbers in this assay, from the lowest: compound 2; then compounds 1, 3 and 4 (each within the scatter of the next).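

In this assay a single substituent on the phenyl does not by itself bring the low number of compound 2: with dimethylamino in place of methyl there is an 18-fold higher number from compound 2 to compound 4 (1.26 log units; beyond the scatter) and this large step shows that the identity of the one substituent matters strongly in this series. Compound 4 does not separate from the other two compounds, as there is a 1.9-fold higher number from compound 1 to compound 4 (0.29 log units; within the scatter) and also a 1.6-fold higher number from compound 3 to compound 4 (0.20 log units; within the scatter) so that, among the four compounds, only compound 2 stands apart from the rest, and 4-(dimethylamino)phenyl offers no measurable gain over 1H-indol-3-yl. No measurement on the groups themselves is at hand to account for the gap between methyl and dimethylamino.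

From the compounds shown here alone, it remains open whether the low number of compound 2 is particular to methyl or extends to other single groups on the phenyl, such as ethyl, methoxy or chlorine. Also open, going by these compounds, is whether a primary amine in place of dimethylamino would stay with compound 4 or come closer to compound 2.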